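This account rests on a few compounds, and the source may have more. Where it says the series, first, only, none or still open, it means among the compounds named here.

In a functional assay on PC-3 cells (Homo sapiens) for inhibition, read by MTT assay, with a stated time of 72 h (a higher number here means a weaker inhibitor, a lower number a stronger inhibitor), compound 1 `CC(C)n1ncc2c(C(=O)NCc3cn(-c4cccc(Br)c4)nn3)cccc21` gives 33700 nM. Compound 2 `CC(C)n1ncc2c(C(=O)NCc3cn(-c4ccc([N+](=O)[O-])cc4)nn3)cccc21` gives no number, only a limit, > 40000 nM. Compound 3 `CCc1ccc(-n2cc(CNC(=O)c3cccc4c3cnn4C(C)C)nn2)cc1` gives 26600 nM.

Among the numbers given, compound 3 holds the lowest one, yet its distance to compound 1 is small: a 1.3-fold lower number from compound 1 to compound 3 (0.10 log units; within the scatter). Compound 4 `CC(C)n1ncc2c(C(=O)NCc3cn(Cc4ccc(C#N)cc4)nn3)cccc21` differs from compound 3 in one place: 4-cyanobenzyl in place of 4-ethylphenyl on an aromatic nitrogen. Among the compounds with values here, two measured steps touch the same position, and both stayed within the scatter: a 1.3-fold lower number from compound 1 to compound 3 (0.10 log units; within the scatter) and an at least 1.5-fold lower number from compound 2 to compound 3 (0.17 log units; that floor lies within the scatter). Neither of them exchanges a directly attached phenyl for a benzyl, so the move to compound 4 is not covered by a measured step. The expectation is therefore no shift beyond the scatter, with a wide margin. The estimate for compound 4 is 30000 nM, from 12000 nM to 80000 nM. This amounts to an expected step of a 1.1-fold higher number from compound 3 to compound 4 (0.05 log units; within the scatter).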

Compound 4, half-maximal inhibitory concentration: 18200 nM
Beside the measured number, compound 4's estimate is 1.6-fold (0.22 log units) above it; low and high end bracket the measured number.
By their numbers in this assay, from the lowest: compounds 4, 3 and 1 (each within the scatter of the next). At a limit, above all of these: compound 2.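

Replacing the directly attached ring with a benzyl on the aromatic nitrogen leaves this assay essentially unmoved: a 1.5-fold lower number from compound 3 to compound 4 (0.16 log units; within the scatter), and a 1.9-fold lower number from compound 1 to compound 4 (0.27 log units; within the scatter). Within the data shown here, only one step passes the scatter, an at least 2.1-fold lower number from compound 2 to compound 4 (0.34 log units; beyond the scatter), and compound 2 carries a limit, not a number: the limit of > 40000 nM in this assay, at which 1 of the 4 values shown sits. This position therefore tolerates a benzyl bearing a nitrile, with no loss seen.

On these data alone, the benzyl and the nitrile enter together, and their separate contributions remain unknown. As far as these compounds go, it also remains open whether a longer chain or an amine on this nitrogen would shift the number beyond the scatter.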